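Furan-2-yl in place of thiophen-2-yl in compound 1

This account rests on a few compounds, and the source may have more. Where it says the series, first, only, none or still open, it means among the compounds named here.

compound 1 `COc1cc(/C=C/C(=O)/C=C/c2cccs2)ccc1OCc1cn(CCCCCOc2cc(=O)oc3ccccc23)nn1` gives 31%
compound 2 `COc1ccc(/C=C/C(=O)/C=C/c2ccc(OCc3cn(CCCOc4cc(=O)oc5ccccc45)nn3)c(OC)c2)cc1` gives 54%
compound 3 `COc1cc(/C=C/C(=O)/C=C/c2cccs2)ccc1OCc1cn(CCCCOc2cc(=O)oc3ccccc23)nn1` gives 41%

In a functional assay on HCT-116 cells (Homo sapiens) for inhibition, read by sulforhodamine B assay, with a stated time of 48 h, tested at 50 uM (a lower number here means less inhibition of growth, a higher number more inhibition of growth at the concentration tested), compound 1 (31%) sits within the scatter of compound 3 (41%), while compound 2 (54%) stands beyond the scatter above compound 1. Compound 4 `COc1cc(/C=C/C(=O)/C=C/c2ccco2)ccc1OCc1cn(CCCCCOc2cc(=O)oc3ccccc23)nn1` differs from compound 1 in one place, with furan-2-yl in place of thiophen-2-yl on a double-bonded chain carbon bound to a double-bonded chain carbon. Among the compounds with values here, the expectation starts from compound 1 (31%), and no measured pair tests this exchange. The estimated a number 2 percentage points higher from compound 1 to compound 4 (within the scatter) is expected to stay within the scatter in this assay, with no firm direction. Compound 4 is estimated at 33%, with 20% to 46% as the expected range.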

Compound 4, percent growth inhibition at one concentration: 37%
Compound 4: middle estimate off by 4 percentage points, on the low side, and the stated range covers the measured number.
By their numbers in this assay, from the lowest: compounds 1, 4 and 3 (each within the scatter of the next); then compound 2.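

In this assay, the exchange of thiophen-2-yl for furan-2-yl on a double-bonded chain carbon bound to a double-bonded chain carbon gives a number 6 percentage points higher from compound 1 to compound 4 (within the scatter), the first step measured at this position. Replacing the ring sulfur with oxygen therefore leaves no change that can be told from the scatter. No supporting measurement bears on this result. On these data alone, what a pyridin-3-yl ring or a dimethylamino group would give at this place stays open, as does whether the same exchange would read alike on the chain of compound 3.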